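Two Measured Aryls Ahead of a Nitrophenyl Analogue

A few compounds are considered here, and "the series" means these few. Any claim that something is new, unique, unknown or untested is made for them only; others in the source may bear on it.

In an ADME assay on HepG2 cells (Homo sapiens) for cytotoxicity, read by MTT assay, with a stated time of 72 h (a higher number here means that more compound is tolerated, a lower number that less compound is tolerated), two compounds have been measured so far:
compound 1 `CC1(c2ccc(-c3ccc(/C(N)=N\O)cc3)cc2)CC(S(=O)(=O)c2ccc(F)cc2)=C(c2ccc(/C(N)=N\O)cc2)O1` gives 15300 nM
compound 2 `CC1(c2ccccc2)CC(S(=O)(=O)c2ccc(F)cc2)=C(c2ccc(/C(N)=N\O)cc2)O1` gives 68300 nM

Compound 2 stands highest of the two numbers in this assay; its nearest neighbour is compound 1, and the gap between them is a 4.5-fold higher number from compound 1 to compound 2 (0.65 log units; beyond the scatter), which comes from a hydrogen atom in place of a larger group on an aromatic carbon.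

Compound 3 `CC1(c2ccc(-c3cccc([N+](=O)[O-])c3)cc2)CC(S(=O)(=O)c2ccc(F)cc2)=C(c2ccc(/C(N)=N\O)cc2)O1` has not been measured. It differs from compound 2 by 3-nitrophenyl in place of hydrogen on an aromatic carbon. Going by the values given here, the only measured step that bears on this change is the one from compound 1 to compound 2, where removing an aromatic group at this same place raised the tolerated concentration by a modest margin beyond the scatter. Putting an aromatic ring back, now a 3-nitrophenyl, is therefore expected to move the number in the opposite direction, by a step of about the same size, so that compound 3 is estimated at a 3.4-fold lower number from compound 2 to compound 3 (0.53 log units; beyond the scatter). On that basis compound 3 is expected to give 20000 nM, with a range from 8000 nM to 50000 nM.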

Compound 3, half-maximal cytotoxic concentration: > 50000 nM
Compound 3: a limit, no number; the forecaster's own chance of this, stated with the estimate: 10%; middle value at least 2.5-fold (0.39 log units) from the limit.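

In this assay compound 3 gives > 50000 nM, which is a limit of the assay and not a number, so the step to it from compound 2 cannot be read and the two cannot be placed in order. The earlier pair alone could suggest that any aromatic ring at this place lowers the number, but compound 3 also carries one there, in the form of 3-nitrophenyl, and exchanging the group of compound 1 for it gives an at least 3.2-fold higher number from compound 1 to compound 3 (0.51 log units; beyond the scatter), so what the ring carries matters here and not merely its presence. Of the compounds shown, only compound 3 reaches this ceiling, which makes it the one result here without a readable size: the limit of > 50000 nM in this assay, at which 1 of the 3 values shown sits.

As far as these compounds go, how far compound 3 actually lies beyond the limit, and whether it differs at all from compound 2, remains open. Also open, from the compounds shown here alone, is where a plain phenyl, or a phenyl ring bearing an amine or a carboxylic acid in place of the nitro group, would fall relative to compound 1 and compound 3.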